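From Amide to Urea: What Compound 3 Should Show

The source may hold more compounds than are shown below. What is called first, only, known or untested is meant among the compounds shown, and "the series" means these compounds.

In a functional assay on K562 cells (Homo sapiens) for inhibition, read by sulforhodamine B assay, with a stated time of 48 h (a higher number here means a weaker inhibitor of growth, a lower number a stronger inhibitor of growth), compound 1 `COc1cc(-c2nn(-c3cccc(NC(=O)Nc4ccc(Cl)c(Cl)c4)c3)cc2-c2ccncc2)ccc1Cl` gives 890 nM, while compound 2 `COc1cc(-c2nn(-c3cccc(NC(=O)c4ccc(Cl)c(C(F)(F)F)c4)c3)cc2-c2ccncc2)ccc1Cl` gives 1610 nM, the higher of the two numbers, although a 1.8-fold higher number from compound 1 to compound 2 (0.26 log units; within the scatter) places the pair within the scatter. Among the compounds with values here, that single step, which exchanged both the aryl group and the link to the carbonyl, is the only one bearing on compound 3 `COc1cc(-c2nn(-c3cccc(NC(=O)Nc4ccc(Cl)c(C(F)(F)F)c4)c3)cc2-c2ccncc2)ccc1Cl`, which differs from compound 2 by (4-chloro-3-(trifluoromethyl)phenyl)amino in place of 4-chloro-3-(trifluoromethyl)phenyl on a carbonyl carbon. Because compound 1 already carries a urea and gives 890 nM, only a small change is expected, a 1.6-fold lower number from compound 2 to compound 3 (0.21 log units; within the scatter), toward a lower number. Compound 3 is estimated at 1000 nM, within a range from 400 nM to 2500 nM.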

Compound 3, concentration for 50% growth inhibition: 1210 nM
The estimate for compound 3 lay 1.2-fold (0.08 log units) below the measured number; the measured number falls inside the stated range.
By their numbers in this assay, from the lowest: compounds 1, 3 and 2 (each within the scatter of the next).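

With the aryl group held fixed, the link alone changes in this assay (a 1.3-fold lower number from compound 2 to compound 3 (0.12 log units; within the scatter)), and with the urea held fixed, the substituent alone changes (a 1.4-fold higher number from compound 1 to compound 3 (0.13 log units; within the scatter)), so the two changes combined in the earlier step are now read separately. Neither separate change lies beyond the scatter, so at this position the amide and urea links cannot be told apart, nor can chloro and trifluoromethyl on this aryl group. Nothing measured here offers an explanation for these small steps.

From the compounds shown here alone, whether an amine or a carboxylic acid in place of trifluoromethyl would give a step beyond the scatter remains open.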